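This account rests on a few compounds, and the source may have more. Where it says the series, first, only, none or still open, it means among the compounds named here.

Three measured compounds share one core. Compound 1 `Cc1ccccc1NC(=O)CSc1nccn1-c1ccc(Cl)cc1` gives 160000 nM in an ADME assay on MT4 cells (Homo sapiens) for cytotoxicity, read by MTT assay; a lower number here means that less compound is tolerated, a higher number that more compound is tolerated. Compound 3 `Cc1ccccc1NC(=O)CSc1nccn1-c1cccc2ccccc12` gives 34600 nM in this assay. For compound 2 `COc1ccc(-n2ccnc2SCC(=O)Nc2ccccc2C)cc1` the assay reports only a limit, > 353000 nM, in this assay (the limit of > 353000 nM in this assay, at which 1 of the 3 values shown sits). Among the measured compounds shown here, the sole measured step is an at least 2.2-fold higher number from compound 1 to compound 2 (0.34 log units; beyond the scatter), a change on the other aryl ring. Compound 4 `COc1ccc(-n2ccnc2SCC(=O)Nc2ccccc2Cl)cc1` differs from compound 2 by chloro in place of methyl on an aromatic carbon, a change within the (2-methylphenyl)amino part; no measured step covers this change, so nothing shown speaks to its size or direction. The expectation therefore rests on compound 2 sitting at its limit, and the step of an at least 1.1-fold lower number from compound 2 to compound 4 (0.07 log units; that floor lies within the scatter) is expected to remain within the scatter. Compound 4 is expected at 300000 nM, with a range from 100000 nM to 800000 nM.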

Compound 4, half-maximal cytotoxic concentration: > 334000 nM
Compound 4: no number, only a limit (the forecaster's own chance of this, stated with the estimate: 50%); middle value at least 1.1-fold (0.04 log units) from the limit.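

In this assay, compound 4 gives only a limit, > 334000 nM. Compound 2 also gives only a limit, > 353000 nM, and the step between the two cannot be read. From the compounds shown here alone, the size and direction of any difference between 2-methylphenyl and 2-chlorophenyl remain open.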